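The compounds below may be only part of what the source reports. "The series", "measured", "known", "first", "only" and "open" are said of these compounds alone.

Compound 2 `O=C(NO)[C@H]1CCCCN1S(=O)(=O)N1CC=C(c2ccccc2)CC1` is the reference point of this comparison. In a functional assay on MONO-MAC-6 cells (Homo sapiens) for inhibition (on this read-out higher numbers stand for weaker inhibition and lower numbers for stronger inhibition), compound 2 gives 240 nM, which is the lowest of the two single numbers available in this assay. Its nearest neighbour is compound 3 `O=C(NO)[C@H]1CCCCN1S(=O)(=O)N1CC=C(c2ccc(Br)cc2)CC1`, which carries bromo in place of hydrogen on an aromatic carbon; in this assay compound 3 gives 1200 nM, and the change amounts to a 5.0-fold higher number from compound 2 to compound 3 (0.70 log units; beyond the scatter). The remaining member of the set, compound 1 `O=C(NO)[C@H]1CCCCN1S(=O)(=O)N1CC=C(c2ccc(Cl)cc2)CC1`, has been run more than once in this assay and gives 430 nM; 480 nM (2 entries), two entries rather than a single number, as recorded in the several entries of compound 1 in this assay, 430 nM; 480 nM (2 entries).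

The compound now in question is compound 4 `O=C(NO)[C@H]1CCCCN1S(=O)(=O)N1CC=C(c2cccc(-c3ccccc3)c2)CC1`, which differs from compound 2 by phenyl in place of hydrogen on an aromatic carbon. Among the compounds with values here, only one measured step, that from compound 2 to compound 3, tells anything about adding a group to this ring; it was modest and went towards weaker inhibition, but it concerns a different group at a different place, so it offers limited guidance. The step from compound 2 to compound 4 is therefore expected to be a 1.9-fold higher number from compound 2 to compound 4 (0.27 log units; within the scatter), small to modest and towards weaker inhibition in this assay. Compound 4 is thus expected to give about 450 nM, with a plausible range from 130 nM to 1600 nM.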

Compound 4, half-maximal inhibitory concentration: 7600 nM
Beside the measured number, compound 4's estimate is 17-fold (1.23 log units) below it, and the stated range ends below it.
By their numbers in this assay, from the lowest: compound 2; then compound 3; then compound 4.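

In this assay, phenyl on an aromatic carbon, meta to a large group, proves far less well tolerated than the earlier ring change suggested: the step is a 32-fold higher number from compound 2 to compound 4 (1.50 log units; beyond the scatter), which is large, whereas the bromo step was only modest at a 5.0-fold higher number from compound 2 to compound 3 (0.70 log units; beyond the scatter). Both steps read from compound 2 run towards weaker inhibition, and neither goes against this, so the aromatic ring of compound 2 is shown to be sensitive to what is added to it, and the size of the effect clearly depends on the group and its place. The only line of support available, the repeat entries of compound 1, has no bearing on this step and gives no explanation for it.

The compounds shown leave open whether a methyl, an amine or a carboxylic acid on the same aromatic carbon would give a step as large as phenyl does. They also leave open whether phenyl on another carbon of that ring, or a cyclohexyl group on this one, would behave in the same way.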